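A few compounds are considered here, and "the series" means these few. Any claim that something is new, unique, unknown or untested is made for them only; others in the source may bear on it.

Values measured in a functional assay on EA.hy 926 cells (Homo sapiens) for cytotoxicity, read by MTT assay, with stated times of 24 h and 12 h (on this read-out lower numbers stand for an effect already at smaller amounts and higher numbers for an effect only at larger amounts of compound), are as follows.

- Compound 1 (`CCOC(=O)/C=C/c1ccc(OC(=O)c2nc(C)c(C)nc2C)c(O)c1`) gives (1700 nM)
- Compound 2 (`COc1cc(/C=C/C(=O)O)cc(OC)c1OC(=O)c1nc(C)c(C)nc1C`) gives (34700 nM)
- Compound 3 (`CCOC(=O)/C=C/c1cc(OC)c(O)c(OC)c1`) gives (67200 nM)

Compound 1 has the lowest number of the three, and the gaps to compound 2 and compound 3 both lie beyond the scatter. Compound 4 (`CCOC(=O)/C=C/c1ccc(OC(=O)c2nc(C)c(C)nc2C)cc1`), not yet measured, is compound 1 with hydrogen in place of hydroxy on an aromatic carbon.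

Among the compounds with values here, no measured pair isolates this change, so any expectation is uncertain. Compound 2 (34700 nM) has no free hydroxy and a higher number than compound 1, but compound 3 (67200 nM) keeps a hydroxy and has the highest number of all. Both also differ from compound 1 elsewhere, so they offer only a weak guide. A moderate rise, modestly beyond the scatter, is expected in this assay (a 2.9-fold higher number from compound 1 to compound 4 (0.47 log units; beyond the scatter)). The estimate for compound 4 is (5000 nM), with an expected range from (1200 nM) to (25000 nM).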

Compound 4, half-maximal effective concentration: 34900 nM
Compound 4: the middle estimate sits 7.0-fold (0.84 log units) below what was measured, and the stated range ends below it.
By their numbers in this assay, from the lowest: compound 1; then compounds 2, 4 and 3 (each within the scatter of the next).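

In this assay, replacing hydroxy with hydrogen on this aromatic carbon, ortho to a large group and meta to a 2-(ethoxycarbonyl)ethenyl group, gives a 21-fold higher number from compound 1 to compound 4 (1.31 log units; beyond the scatter) as a single-place change. Compound 2 and compound 3 each differ from compound 1 in other places as well, whereas this pair isolates the hydroxy and shows that the low number of compound 1 does not survive its loss. No measurement shown explains why this hydroxy makes such a difference.

From the compounds shown here alone, it remains open whether another group on the same carbon, such as an amine or a fluorine, would keep the low number, or whether a hydroxy elsewhere on the ring would do so. Also open, going by these compounds, is whether the step keeps its size when a longer chain replaces the ethyl of the ester.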